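A few compounds are considered here, and "the series" means these few. Any claim that something is new, unique, unknown or untested is made for them only; others in the source may bear on it.

Measured so far:
compound 1, `O=C1c2c[n+]([O-])c3ccccc3c2C(=O)c2c1c1ccccc1n2Cc1cn([C@@H]2C[C@H](O)[C@@H](CO)O2)nn1`, 120 nM
compound 2, `O=C1c2c[n+]([O-])c3ccccc3c2C(=O)c2c1c1ccccc1n2Cc1cn([C@H]2O[C@H](CO)[C@@H](O)[C@H]2O)nn1`, 2680 nM

Going by the values given here, in a functional assay on A549 cells (Homo sapiens) for cytotoxicity, read by MTT assay, with a stated time of 72 h (a higher number here means a weaker inhibitor, a lower number a stronger inhibitor), compound 2 gives the highest of the two numbers; its nearest neighbour is compound 1, and the one measured step, a 22-fold higher number from compound 1 to compound 2 (1.35 log units; beyond the scatter), separates them. That step is a hydroxy in place of hydrogen on a saturated ring carbon and it is large and well beyond the scatter.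

Compound 3, `CC1(C)OC[C@@H](Cn2cc(Cn3c4c(c5ccccc53)C(=O)c3c[n+]([O-])c5ccccc5c3C4=O)nn2)O1`, is not yet measured. It differs from compound 2 by (2,2-dimethyl-1,3-dioxolan-4-yl)methyl in place of 3,4-dihydroxy-5-(hydroxymethyl)oxolan-2-yl on an aromatic nitrogen. Among the compounds with values here, the only step that bears on this is the one from compound 1 to compound 2, which shows that adding a hydroxy on the saturated ring raised the number strongly; compound 3 removes all hydroxy groups of that ring and replaces the ring with one carrying no hydrogen-bond donors. On that evidence a lower number is expected for compound 3 in this assay, with a step estimated at a 7.7-fold lower number from compound 2 to compound 3 (0.88 log units; beyond the scatter), though the new group is not a simple reversal of the measured change, so the range is kept wide. Compound 3 is therefore expected to give about 350 nM, between 70 nM and 1800 nM.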

Compound 3, half-maximal inhibitory concentration: 4700 nM
For compound 3 the middle estimate is 13-fold (1.13 log units) below the measured one; the measured number lies above the stated range.
By their numbers in this assay, from the lowest: compound 1; then compounds 2 and 3 (each within the scatter of the next).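

In this assay, replacing 3,4-dihydroxy-5-(hydroxymethyl)oxolan-2-yl with (2,2-dimethyl-1,3-dioxolan-4-yl)methyl on this aromatic nitrogen leaves compound 2 and compound 3 within the scatter of each other (a 1.8-fold higher number from compound 2 to compound 3 (0.24 log units; within the scatter)), even though the entering group has 0 hydrogen-bond donors and a different five-membered ring. The hydroxy trend suggested by the earlier pair therefore does not extend across the series: compound 3 has no hydroxy group on this substituent, yet it stands well apart from compound 1 (a 39-fold higher number from compound 1 to compound 3 (1.59 log units; beyond the scatter)), and so goes against any reading in which fewer hydroxy groups simply give a lower number. Among the three compounds, only the 4-hydroxy-5-(hydroxymethyl)oxolan-2-yl group of compound 1 is clearly separated from the others, and no supporting measurement explains this.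

The compounds shown leave open which part of that group matters, the ring hydroxy or the hydroxymethyl. They also leave open how a simple open chain ending in a primary amine or a carboxylic acid would behave on the same aromatic nitrogen.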